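This account rests on a few compounds, and the source may have more. Where it says the series, first, only, none or still open, it means among the compounds named here.

Compound 1 `Cc1ccc(NC(=O)C2CCN(C/C=C/c3ccccc3)CC2)cc1` gives 24100 nM in a functional assay on MGC-803 cells (Homo sapiens) for inhibition, read by MTT assay, with a stated time of 72 h; a higher number here means a weaker inhibitor, a lower number a stronger inhibitor; compound 2 `CC(C)c1ccc(NC(=O)C2CCN(C/C=C/c3ccccc3)CC2)cc1` gives 5200 nM.

Among the compounds with values here, compound 2 holds the lowest of the two numbers, and the only step seen, a 4.6-fold lower number from compound 1 to compound 2 (0.67 log units; beyond the scatter), separates it from compound 1. Compound 3 `COc1ccc(NC(=O)C2CCN(C/C=C/c3ccccc3)CC2)cc1` differs from compound 2 by methoxy in place of isopropyl on an aromatic carbon. That step bears on this pair only indirectly: the change from methyl to isopropyl brought a clear fall, and methoxy is closer in size to methyl than to isopropyl. The number for compound 3 is therefore expected to rise, with a 2.9-fold higher number from compound 2 to compound 3 (0.46 log units; beyond the scatter) as the estimated step. Compound 3 is estimated at 15000 nM, between 5000 nM and 45000 nM.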

Compound 3, half-maximal inhibitory concentration: 58200 nM
Compound 3: the middle estimate sits 3.9-fold (0.59 log units) below what was measured; measured number above the stated range.
By their numbers in this assay, from the lowest: compound 2; then compound 1; then compound 3.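

In this assay, the change from 4-isopropylphenyl to 4-methoxyphenyl gives an 11-fold higher number from compound 2 to compound 3 (1.05 log units; beyond the scatter) and is the largest step seen at this position. Methoxy also differs from methyl, with a 2.4-fold higher number from compound 1 to compound 3 (0.38 log units; beyond the scatter) and thus the highest number of the three, so the numbers do not simply run along a line from methyl to isopropyl. No measurement shown here explains why methoxy stands apart. Still open, going by these compounds, is how a tert-butyl group, a chlorine atom or an ethoxy group would compare at this position on the ring.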